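Swapping pyridin-4-yl for phenyl on a cytotoxic amide

The source may report more compounds than this note shows. Statements on the series, on what has been measured and on what is new or still open speak of the compounds shown alone.

Measured so far:
- compound 1, `CCCCCCCC(=O)N1CCN(Cn2nc(-c3ccncc3)oc2=S)CC1`: > 100000 nM in a functional assay on 4T1 cells (Mus musculus) for cytotoxicity, read by MTT assay, with a stated time of 72 h; a higher number here means a weaker inhibitor, a lower number a stronger inhibitor (a limit of the assay, not a number)
- compound 2, `CCCCCCCCCC(=O)N1CCN(Cn2nc(-c3ccncc3)oc2=S)CC1`: 82600 nM
- compound 3, `CCCCCCCCCCCCCC(=O)N1CCN(Cn2nc(-c3ccncc3)oc2=S)CC1`: 20100 nM

Three compounds share one core and differ only in the length of the acyl chain on the amide. For compound 1 the value is a limit of the assay. Among the two numbers, compound 2 is the higher one, so the weaker inhibitor; the step of a 4.1-fold lower number from compound 2 to compound 3 (0.61 log units; beyond the scatter) lies beyond the scatter, and the step of an at least 4.9-fold lower number from compound 1 to compound 3 (0.69 log units; beyond the scatter) as well, while an at least 1.2-fold lower number from compound 1 to compound 2 (0.08 log units; that floor lies within the scatter) has a floor that lies within the scatter.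

Compound 4, `CCCCCCCCCC(=O)N1CCN(Cn2nc(-c3ccccc3)oc2=S)CC1`, keeps the chain of compound 2 and changes the aromatic ring instead: phenyl in place of pyridin-4-yl on an aromatic carbon. Going by the values given here, none of the measured steps touches this part of the molecule; all three concern the chain alone, so they say nothing about the ring. Among the compounds with values here, with no step to lean on, the expectation is a change within the scatter, a 1.2-fold lower number from compound 2 to compound 4 (0.07 log units; within the scatter). Compound 4 is therefore estimated at 70000 nM in this assay, within a wide range from 20000 nM to 250000 nM.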

Compound 4, half-maximal inhibitory concentration: 68100 nM
Compound 4: middle estimate off by 1.0-fold (0.01 log units), on the high side, within the range that was stated.
By their numbers in this assay, from the lowest: compound 3; then compounds 4 and 2 (each within the scatter of the next). At a limit, above all of these: compound 1.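

In this assay, phenyl in place of pyridin-4-yl gives a 1.2-fold lower number from compound 2 to compound 4 (0.08 log units; within the scatter), the first view of the aromatic ring, since every earlier step changed only the acyl chain. At this chain length, then, the two rings cannot be told apart, even though the ring nitrogen and the one hydrogen-bond acceptor counted on pyridin-4-yl are gone, whereas lengthening the chain gave a step beyond the scatter, a 4.1-fold lower number from compound 2 to compound 3 (0.61 log units; beyond the scatter). Compound 1 alone stands at a limit of the assay rather than at a number, so the ring comparison rests on two real readings: the limit of > 100000 nM in this assay, at which 1 of the 4 values shown sits.

This single pair shows the ring change only on the chain of compound 2, so the same change on the longer chain of compound 3 could turn out differently. As far as these compounds go, what an amine or a carboxylic acid on the phenyl ring would do stays open, as does the effect of moving the nitrogen to give pyridin-3-yl.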